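The source may hold more compounds than are shown below. What is called first, only, known or untested is meant among the compounds shown, and "the series" means these compounds.

Of the compounds shown here, three sharing one core have been tested in a functional assay on the whole organism for inhibition, with Rattus norvegicus as the target, read by paw edema, with stated times of 30 min and 3 h, at a dose of 0.28 mmol/kg by the oral route; on this read-out lower numbers stand for less inhibition and higher numbers for more inhibition at the one dose given (going by the name of the read-out). Compound 1 `COc1ccc(-n2nc(C(=O)Nc3ccc(C)cc3)nc2-c2cc(OC)c(OC)c(OC)c2)cc1` gives 77%. Compound 2 `COc1ccc(-n2nc(C(=O)Nc3ccccc3C)nc2-c2cc(OC)c(OC)c(OC)c2)cc1` gives 64%, and compound 3 `COc1ccc(-n2nc(C(=O)Nc3ccc(O)cc3)nc2-c2cc(OC)c(OC)c(OC)c2)cc1` gives 64%. Compound 2 thus stands level with compound 3 at the digits shown, the two together being the lowest of the three numbers, while compound 1 sits above both: the step of a number 13 percentage points lower from compound 1 to compound 2 (beyond the scatter) and the step of a number 13 percentage points lower from compound 1 to compound 3 (beyond the scatter) are each beyond the scatter, whereas the step of no change at the digits printed from compound 2 to compound 3 (within the scatter) is within it.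

Compound 4 `COc1ccc(-n2nc(C(=O)Nc3ccccc3)nc2-c2cc(OC)c(OC)c(OC)c2)cc1` is compound 2 with one change: hydrogen in place of methyl on an aromatic carbon. Going by the values given here, no measured step removes this methyl outright; the nearest guide is the step of a number 13 percentage points lower from compound 1 to compound 2 (beyond the scatter), which shows that placing the methyl at the 2-position rather than the 4-position costs a modest amount. Taking the methyl away altogether might recover part of that, but the step of no change at the digits printed from compound 2 to compound 3 (within the scatter) shows that an unrelated change at this ring made no difference beyond the scatter, so a small effect, if any, is the more cautious expectation.

Compound 4 is therefore expected to give 68% in this assay, with a range from 56% to 80%, which corresponds to an expected step of a number 4 percentage points higher from compound 2 to compound 4 (within the scatter).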

Compound 4, a percentage reported as inhibition, in the whole organism at one dose (the size of the read-out at that dose, not a potency): 69%
The estimate for compound 4 lay 1 percentage points below the measured number; the measured number falls inside the stated range.
By their numbers in this assay, from the lowest: compounds 2, 3, 4 and 1 (each within the scatter of the next, the first and the last beyond it).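

Taking the methyl off the 2-methylphenyl ring in this assay gives a number 5 percentage points higher from compound 2 to compound 4 (within the scatter), so at this place on the ring the methyl cannot be told apart from plain hydrogen. The bare phenyl ring also stays within the scatter of the other two substituted rings, with a number 5 percentage points higher from compound 3 to compound 4 (within the scatter) for hydrogen in place of hydroxy and a number 8 percentage points lower from compound 1 to compound 4 (within the scatter) for hydrogen in place of the methyl of the 4-methylphenyl ring, so only compound 1 and the pair compound 2 and compound 3 stand apart beyond the scatter, with compound 4 lying within reach of all of them. No measurement is available that could explain these numbers.

Going by these compounds, whether a bulkier or charged group on this phenyl ring, such as a tert-butyl group, an amine or a carboxylic acid, would move the number beyond the scatter remains open. Also open, on these data alone, is how the compounds would compare across several doses, since each number here describes a single dose and is not a potency.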